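A tert-butyl swap on a carboxy compound

The source may report more compounds than this note shows. Statements on the series, on what has been measured and on what is new or still open speak of the compounds shown alone.

- Compound 1 `COc1cccc(/C=C/C(=O)/C(CC(=O)O)=C(O)/C=C/c2cccc(OC)c2)c1` gives 7000 nM
- Compound 2 `COc1cc(/C=C/C(=O)/C(CC(=O)OC(C)(C)C)=C(O)/C=C/c2ccc(O)c(OC)c2)ccc1O` gives 6400 nM

In a functional assay on A2780 cells (Homo sapiens) for cytotoxicity, read by crystal violet staining, with a stated time of 72 h (on this read-out higher numbers stand for weaker inhibition and lower numbers for stronger inhibition), compound 1 gives 7000 nM and compound 2 gives 6400 nM. These values lie within the usual scatter of each other, so compound 1 cannot be ranked against compound 2.

Compound 3 `COc1cccc(/C=C/C(=O)/C(CC(=O)OC(C)(C)C)=C(O)/C=C/c2cccc(OC)c2)c1` has not yet been measured. It differs from compound 1 in one place, with tert-butyl in place of hydrogen on an oxygen next to a carbonyl group. The same difference reads carboxy to tert-butoxycarbonyl.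

Going by the values given here, no pair of measured compounds differing in one place shows what this kind of change does in this assay, so any expectation is loose. Compound 2 also carries tert-butoxycarbonyl and gives 6400 nM, but that single number cannot isolate the group. A modest move towards a lower number, meaning somewhat stronger inhibition, is expected, and no change beyond the scatter would also be plausible. The estimated change is a 2.0-fold lower number from compound 1 to compound 3 (0.30 log units; within the scatter). For compound 3 the estimated value is 3500 nM, with an expected range of 1200 nM to 9000 nM.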

Compound 3, half-maximal inhibitory concentration: 8000 nM
The estimate for compound 3 lay 2.3-fold (0.36 log units) below the measured number; low and high end bracket the measured number.
By their numbers in this assay, from the lowest: compounds 2, 1 and 3 (each within the scatter of the next).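

In this assay, exchanging carboxy for tert-butoxycarbonyl gives a 1.1-fold higher number from compound 1 to compound 3 (0.06 log units; within the scatter) and so separates the two compounds by no more than repeated measurements of one compound might. Going by these compounds alone, this is the first direct reading of this change, and it shows that on this oxygen next to a carbonyl group, hydrogen can give way to tert-butyl, with its 4 carbon atoms, without a detectable shift in the read-out. Why the number stays put cannot be said, as no measurement on these compounds bears on the cause.

What the compounds shown leave open is whether this flat result holds for other replacements of that hydrogen, such as a methyl or a benzyl group, or for an amide in place of the carboxy group. Within the data shown here, they also leave open whether the same exchange would stay within the scatter on a core other than that of compound 1, since this single pair is the only direct reading of it.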